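Chain change on the shared core: methoxymethyl to ethynyl

The source may report more compounds than this note shows. Statements on the series, on what has been measured and on what is new or still open speak of the compounds shown alone.

In a functional assay on MCF7 cells (Homo sapiens) for cytotoxicity (on this read-out lower numbers stand for an effect already at smaller amounts and higher numbers for an effect only at larger amounts of compound), compound 1 `COc1cc(Cc2nc3c(N)ncnc3n2CCCCCO)cc(OC)c1OC` gives 84900000 nM. Compound 2 `COCCCn1c(Cc2cc(OC)c(OC)c(OC)c2)nc2c(N)nc(F)nc21` gives 72600000 nM in this assay; this lies within the scatter of the number for compound 1, so the two measured compounds cannot be told apart. Compound 3 `C#CCCn1c(Cc2cc(OC)c(OC)c(OC)c2)nc2c(N)nc(F)nc21` differs from compound 2 by ethynyl in place of methoxymethyl on a saturated chain carbon, two bonds along the chain from an aromatic nitrogen. Among the measured compounds shown here, no step between measured compounds covers this change, and the two measured chains show nothing to separate them, so no step beyond the scatter is expected in this assay. Compound 3 is expected to give 75000000 nM, between 25000000 nM and 250000000 nM. The expected step is a 1.0-fold higher number from compound 2 to compound 3 (0.01 log units; within the scatter), none beyond the scatter.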

Compound 3, half-maximal effective concentration: 286000000 nM
Compound 3: the middle estimate sits 3.8-fold (0.58 log units) below what was measured; the whole stated range lies below it.
By their numbers in this assay, from the lowest: compounds 2 and 1 (each within the scatter of the next); then compound 3.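

In this assay, among the compounds shown here, this position is not silent: ethynyl in place of methoxymethyl gives a 3.9-fold higher number from compound 2 to compound 3 (0.60 log units; beyond the scatter), a change the earlier compounds, with no step between them, could not reveal. This rests on a single pair, so it holds only for this change on a saturated chain carbon, two bonds along the chain from an aromatic nitrogen. No measurement at hand accounts for the step.

On these data alone, whether the step follows the triple bond or the loss of the methoxymethyl oxygen remains open. An amine or a carboxylic acid in the same place, or a longer chain, would show how the number responds to other groups.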